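This account rests on a few compounds, and the source may have more. Where it says the series, first, only, none or still open, it means among the compounds named here.

Compound 2 `N#CC1=C(NC(=O)c2ccccc2)N(c2ccc(S(N)(=O)=O)cc2)C2=C(C(=O)CCC2)C1c1ccc(Cl)cc1Cl` carries a benzamido group on a double-bonded ring carbon of the shared core. In a functional assay on Ehrlich cells (Mus musculus) for cytotoxicity, read by trypan blue exclusion, with a stated time of 2 h, tested at 10 ug/mL (a lower number here means a weaker effect, a higher number a stronger effect of the compound at the concentration tested), compound 2 gives 50%, the highest of the three numbers measured. Compound 1 `N#CC1=C(NC(=O)C2CC2)N(c2ccc(S(N)(=O)=O)cc2)C2=C(C(=O)CCC2)C1c1ccc(Cl)cc1Cl`, with cyclopropyl in place of phenyl on the carbonyl carbon, gives 20%, and compound 3 `CN(C)c1ccc(/C=N/C2=C(C#N)C(c3ccc(Cl)cc3Cl)C3=C(CCCC3=O)N2c2ccc(S(N)(=O)=O)cc2)cc1`, in which the benzamido is exchanged for a larger ring-bearing group, gives 10%. Both steps involving compound 2 lie beyond the scatter: a number 30 percentage points higher from compound 1 to compound 2 (beyond the scatter) and a number 40 percentage points lower from compound 2 to compound 3 (beyond the scatter). Between compound 1 and compound 3 the step stays within the scatter: a number 10 percentage points lower from compound 1 to compound 3 (within the scatter).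

Compound 4 `CCO/C=N/C1=C(C#N)C(c2ccc(Cl)cc2Cl)C2=C(CCCC2=O)N1c1ccc(S(N)(=O)=O)cc1` has not yet been measured. Against compound 2 the change is a group of 5 heavy atoms (3 carbon, 1 nitrogen, 1 oxygen; no ring) in place of a group of 9 heavy atoms (7 carbon, 1 nitrogen, 1 oxygen; one six-membered aromatic ring of carbon only), on a double-bonded ring carbon. The two measured steps that touch this position point the same way: removing the phenyl for cyclopropyl lowered the number, and exchanging the whole benzamido for a ring-bearing group lowered it further. The entering group of compound 4 is smaller than either and lacks the amide hydrogen donor, so a fall from compound 2 of comparable size is expected, without any measured step to fix its exact extent. Compound 4 is therefore estimated to give 15%, within 5% to 35%, a step of a number 35 percentage points lower from compound 2 to compound 4 (beyond the scatter) from compound 2.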

Compound 4, a percentage reported as activity, at one concentration (the size of the read-out at that concentration, not a potency): 30%
Estimate against measurement, compound 4: 15 percentage points below; measured number inside the range.
By their numbers in this assay, from the lowest: compounds 3, 1 and 4 (each within the scatter of the next, the first and the last beyond it); then compound 2.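

In this assay, among these compounds, the step of a number 20 percentage points higher from compound 3 to compound 4 (beyond the scatter) is the first comparison with the carbon double-bonded to nitrogen kept in place, and it shows that the number depends on what that carbon carries, not only on whether the benzamido is present. The step of a number 20 percentage points lower from compound 2 to compound 4 (beyond the scatter) shows that the exchange of benzamido need not bring in a large ring-bearing group to lower the number, and compound 2 now stands beyond the scatter of all three other compounds, so among these four groups only benzamido reaches that level. The step of a number 10 percentage points higher from compound 1 to compound 4 (within the scatter) stays within the scatter, so compound 1 and compound 4 cannot be told apart here, although only compound 1 keeps the amide hydrogen, and that hydrogen alone does not separate the two.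

No measurement at hand accounts for any of these steps. The compounds shown leave open how a free amine or an acetamido group on the same ring carbon would read, and whether a butoxy chain in place of ethoxy would shift the number.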